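This account rests on a few compounds, and the source may have more. Where it says the series, first, only, none or still open, it means among the compounds named here.

Working notes on the series. The measured set comprises compound 1 `C/C(=N\NC(=S)Nc1ccccc1[N+](=O)[O-])c1ccccn1`, compound 2 `C/C(=N\NC(=S)Nc1ccc(Cl)cc1)c1ccccn1` and compound 3 `C/C(=N\NC(=S)Nc1ccccc1Cl)c1ccccn1`. In a functional assay on T98G cells (Homo sapiens) for cytotoxicity, read by MTT assay, with a stated time of 48 h (a lower number here means a stronger inhibitor, a higher number a weaker inhibitor), compound 1 gives 6.61 nM, compound 2 gives 5.9 nM and compound 3 gives 1.1 nM. Compound 3 thus holds the lowest of the three numbers; its nearest neighbour is compound 2 and its furthest compound 1, both gaps lying beyond the scatter. One single-point step has been measured within the set: a 6.0-fold lower number from compound 1 to compound 3 (0.78 log units; beyond the scatter), a modest change.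

Compound 4 `C/C(=N\NC(=S)Nc1ccccc1)c1ccccn1` is next to be measured. Its difference from compound 3 is hydrogen in place of chloro on an aromatic carbon. Among the compounds with values here, no measured pair shares this change, so the measured step bears on it only indirectly: it shows that what sits on that aromatic carbon shifts the number modestly, and the values of compound 2 and compound 3 show that chloro at another site also leaves a gap beyond the scatter. Within the data shown here, removing chloro altogether has no precedent here. A modest rise toward the level of compound 1 and compound 2 is expected rather than a fall, because compound 3 at 1.1 nM is the lowest number and the only one bearing chloro at that place. For compound 4 the expected value is 4 nM, with a range from 1.2 nM to 13 nM. The implied step is expected to be a 3.6-fold higher number from compound 3 to compound 4 (0.56 log units; beyond the scatter), a change that would lie beyond the scatter but not far beyond it.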

Compound 4, half-maximal inhibitory concentration: 6.81 nM
Estimate against measurement, compound 4: 1.7-fold (0.23 log units) below, within the range that was stated.
By their numbers in this assay, from the lowest: compound 3; then compounds 2, 1 and 4 (each within the scatter of the next).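

In this assay, hydrogen in place of the chloro that sits ortho to a large group gives a clear step (a 6.2-fold higher number from compound 3 to compound 4 (0.79 log units; beyond the scatter)), so the low number of compound 3 depends on chloro on this aromatic carbon and not on the shared core alone. The other two groups do not separate from hydrogen: replacing the chloro of compound 2 gives one step (a 1.2-fold higher number from compound 2 to compound 4 (0.06 log units; within the scatter)) and replacing the nitro of compound 1 gives another (a 1.0-fold higher number from compound 1 to compound 4 (0.01 log units; within the scatter)), both within the scatter. Among these four compounds, only chloro on this carbon stands apart from hydrogen, and compound 2 shows that the presence of chloro alone does not suffice, while compound 1 shows that another group on the same carbon does not reproduce the result.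

Still open, on these data alone, is whether fluoro, bromo, methyl or an amine on this aromatic carbon would give a number near that of compound 3 or near that of compound 4. No supporting evidence accompanies these numbers, so what lies behind the step from chloro to hydrogen cannot be said from the data at hand.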